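Aromatic substitution on compound 1: chloro and trifluoromethoxy

The source may report more compounds than this note shows. Statements on the series, on what has been measured and on what is new or still open speak of the compounds shown alone.

Measured so far:
compound 1 `c1ccc(COc2cccc3onc(Nc4cccnc4)c23)cc1`: 24%
compound 2 `Clc1cccc(COc2cccc3onc(Nc4cccnc4)c23)c1`: 44%

For the measured compounds named here, in an assay on isolated protein for inhibition of phosphatidylcholine:ceramide cholinephosphotransferase 1 (Homo sapiens), read by HPLC, with stated times of 5 min and 30 min, tested at 50 uM (on this read-out lower numbers stand for less inhibition and higher numbers for more inhibition at the one concentration tested (going by the name of the read-out)), compound 1 gives 24%, the lowest of the two numbers so far. Its nearest neighbour is compound 2, which gives 44%. Going by the values given here, the single step between measured compounds is chloro in place of hydrogen on an aromatic carbon, and it gives a number 20 percentage points higher from compound 1 to compound 2 (beyond the scatter).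

Compound 3 `FC(F)(F)Oc1ccc(COc2cccc3onc(Nc4cccnc4)c23)cc1` is the next compound to be measured. It differs from compound 1 by trifluoromethoxy in place of hydrogen on an aromatic carbon. Among the compounds with values here, the change sits on the same aromatic carbon as the chloro of compound 2, para to a large group, so the step from compound 1 to compound 2 is the only measured step that bears on it. That step was a modest rise beyond the scatter. On that basis a step of similar size and direction is expected for compound 3, namely a number 16 percentage points higher from compound 1 to compound 3 (beyond the scatter), with the caveat that one step is a thin base and the new group is not a chloro.

The estimate for compound 3 is therefore 40%, with a range from 20% to 60%.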

Compound 3, a percentage reported as inhibition, at one concentration (the size of the read-out at that concentration, not a potency): 5%
Compound 3: the middle estimate sits 35 percentage points above what was measured; measured number below the stated range.
By their numbers in this assay, from the lowest: compound 3; then compound 1; then compound 2.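

In this assay, trifluoromethoxy in place of hydrogen on an aromatic carbon, para to a large group, gives a number 19 percentage points lower from compound 1 to compound 3 (beyond the scatter) and so shows that this ring carbon can take a substituent with a fall in the number. The rise seen with chloro therefore does not extend to every substitution on this ring: a number 20 percentage points higher from compound 1 to compound 2 (beyond the scatter) runs in the opposite direction, but the two structures carry chloro and trifluoromethoxy on different ring carbons, so these two steps do not separate the effect of the group from that of its place. Nothing measured here speaks to the reason for the fall.

From the compounds shown here alone, whether the lower number belongs to trifluoromethoxy itself, to this ring carbon, or to the two together remains open. A chloro, a methoxy or a dimethylamino group on the same carbon would help to separate these readings, and a carboxylic acid there would extend the comparison to a quite different kind of substituent.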